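The compounds below may be only part of what the source reports. "The series", "measured", "known", "first", "only" and "open" are said of these compounds alone.

Of the compounds shown here, two built on a shared core have been tested in a functional assay on PC-3 cells (Homo sapiens) for antiproliferative activity, read by MTT assay, with a stated time of 48 h; a lower number here means a stronger inhibitor, a higher number a weaker inhibitor. Compound 1, `Cc1cnc(Nc2ccc(S(N)(=O)=O)cc2)nc1Nc1nc2ccccc2s1`, gives in this assay a reading of > 50000 nM, which is a limit of the assay and not a number. For the measured compounds named here, compound 2, `CS(=O)(=O)c1ccc(Nc2nccc(Nc3nc4ccccc4s3)n2)cc1`, gives in this assay a value of 1710 nM, the only number among the two results. Compound 3, `NS(=O)(=O)c1ccc(Nc2nccc(Nc3nc4ccccc4s3)n2)cc1`, has not yet been measured. It differs from compound 2 in a single place: amino in place of methyl on a sulfonyl sulfur. Going by the values given here, no measured pair shows this exact change, so its size has to be guessed. Compound 1 also carries a sulfamoyl group, though it differs from compound 3 in a second place as well. Compound 3 is expected to be somewhat weaker than compound 2, a step of a 2.3-fold higher number from compound 2 to compound 3 (0.37 log units; beyond the scatter), with an estimate of 4000 nM, likely between 1000 nM and 20000 nM.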

Compound 3, half-maximal inhibitory concentration: 3100 nM
Compound 3: middle estimate off by 1.3-fold (0.11 log units), on the high side; measured number inside the range.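

In this assay, the change from methylsulfonyl to sulfamoyl gives a 1.8-fold higher number from compound 2 to compound 3 (0.26 log units; within the scatter), so at this place on the sulfonyl sulfur the two groups cannot be told apart. A much larger difference comes with hydrogen in place of methyl on an aromatic carbon, an at least 16-fold lower number from compound 1 to compound 3 (1.20 log units; beyond the scatter), so the sulfamoyl group that compound 1 and compound 3 share does not by itself go with a reading as high as that of compound 1. The reading of compound 1 is a limit of the assay and not a number, so this step gives only a minimum size: the limit of > 50000 nM in this assay, at which 1 of the 3 values shown sits.

On these data alone, whether a larger group on the sulfonyl sulfur, such as dimethylamino or ethyl, would separate from these two remains open. As far as these compounds go, a single pair carries the methyl step, so it is also open how an ethyl or a chlorine on that aromatic carbon would read.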